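Series notes: cyano in place of ethyl, compound 3

The source may hold more compounds than are shown below. What is called first, only, known or untested is meant among the compounds shown, and "the series" means these compounds.

Two compounds have numbers in an assay on brain for binding affinity to Neuronal acetylcholine receptor; alpha4/beta2 (Rattus norvegicus), read by radioligand binding; on this read-out higher numbers stand for weaker inhibition and lower numbers for stronger inhibition. Compound 1 `Brc1ccc(OC[C@@H]2CCN2)cn1` gives 0.021 nM. Compound 2 `CCc1ccc(OC[C@@H]2CCN2)cn1` gives 19 nM. Compound 2 therefore stands at the higher of the two numbers; its nearest neighbour is compound 1, and the step of a 900-fold higher number from compound 1 to compound 2 (2.96 log units; beyond the scatter) separates them.

Compound 3 `N#Cc1ccc(OC[C@@H]2CCN2)cn1` has not yet been measured. The change from compound 2 to compound 3 is cyano in place of ethyl on an aromatic carbon. Within the data shown here, only one measured step bears on it, the one at the same aromatic carbon: a 900-fold higher number from compound 1 to compound 2 (2.96 log units; beyond the scatter), in which ethyl in place of bromo moved the number a long way upward. Among the measured compounds shown here, no measured step joins bromo to cyano directly, so the size of any return cannot be read from the data. Because removing the ethyl undoes the change that gave a 900-fold higher number from compound 1 to compound 2 (2.96 log units; beyond the scatter), a lower number is expected for compound 3, though not necessarily back to the number of compound 1. The expected step in this assay is a 63-fold lower number from compound 2 to compound 3 (1.80 log units; beyond the scatter). Compound 3 is estimated at 0.3 nM, with a range from 0.03 nM to 3 nM.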

Compound 3, inhibition constant: 1.9 nM
Compound 3: the middle estimate sits 6.3-fold (0.80 log units) below what was measured; measured number inside the range.
By their numbers in this assay, from the lowest: compound 1; then compound 3; then compound 2.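

Ethyl and cyano each put 2 heavy atoms on this aromatic carbon next to the ring nitrogen, yet a 10-fold lower number from compound 2 to compound 3 (1.00 log units; beyond the scatter) in this assay, so the heavy-atom count of the group does not by itself set the number here. Earlier, the position was known only from a single drop from bromo to ethyl; with a third group it now shows an intermediate level, since the return from ethyl is only partial and a 90-fold higher number from compound 1 to compound 3 (1.96 log units; beyond the scatter). Among these three compounds, bromo gives the lowest number, cyano the middle one and ethyl the highest, and the swap from ethyl to cyano also adds a triple bond and a hydrogen-bond acceptor, which cannot be told apart as contributors from this one change. Nothing available explains why the three groups fall in this order.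

The compounds shown leave open whether the low number of compound 1 is particular to bromo or is shared by chloro or iodo at the same carbon. They also leave open how a methoxy group, an amine or a longer chain such as propyl would rank against bromo, cyano and ethyl.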